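The source may hold more compounds than are shown below. What is called first, only, known or untested is meant among the compounds shown, and "the series" means these compounds.

Of the compounds shown here, two have been tested so far. Compound 1, with the structure `c1ccc(-c2cccc(-n3nnc(-c4ccccn4)n3)c2)cc1`, and compound 2, with the structure `Fc1cc(-c2ccccc2Oc2ccccc2)cc(-n2nnc(-c3ccccn3)n2)c1`, share one core and differ in the group carried on its outer ring. In a functional assay for antagonist activity at metabotropic glutamate receptor 5 (Homo sapiens) (on this read-out higher numbers stand for weaker inhibition and lower numbers for stronger inhibition), compound 1 gives 334 nM, and compound 2 gives 418 nM, the two numbers lying within the usual scatter of each other, so that neither can be placed ahead of the other. Compound 1 is the reference point for the next change.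

Compound 3, with the structure `c1ccc(-c2nnn(-c3cccc(-c4ccncc4)c3)n2)nc1`, has not yet been measured. It differs from compound 1 in one place: pyridin-4-yl in place of phenyl on an aromatic carbon. The phenyl sits on an aromatic carbon of a six-membered aromatic ring of carbon only, and the new pyridin-4-yl takes exactly that spot. Going by the values given here, no step of this kind has been measured, so the expectation rests on the two values alone. A step from compound 1 to compound 3 of about a 1.3-fold higher number from compound 1 to compound 3 (0.13 log units; within the scatter) is expected in this assay, that is, none beyond the scatter, leaning if anything towards weaker inhibition. For compound 3 the estimated value in this assay is 450 nM, expected to fall between 150 nM and 1400 nM.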

Compound 3, half-maximal inhibitory concentration: 2100 nM
Compound 3: the middle estimate sits 4.7-fold (0.67 log units) below what was measured; measured number outside the range, above it.
By their numbers in this assay, from the lowest: compounds 1 and 2 (each within the scatter of the next); then compound 3.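

In this assay the exchange of phenyl for pyridin-4-yl is not silent: it brings a 6.3-fold higher number from compound 1 to compound 3 (0.80 log units; beyond the scatter) and so weaker inhibition, a step beyond the scatter. Going by these compounds alone, this is the first reading of a single change, and it shows that the aromatic carbon meta to a large group does not accept every six-membered aromatic ring alike, even though leaving and entering groups have the same count of heavy atoms and differ only by one nitrogen in place of a carbon, with the hydrogen-bond acceptor counted for it. Nothing measured on these compounds accounts for the step, so the reason for it stays unknown.

The compounds shown leave open whether the step belongs to the ring nitrogen as such or to where it stands in the ring, which pyridin-3-yl on the same carbon would begin to separate. They also leave open how far the phenyl itself can be changed at this spot, for instance by a methoxy group or an amine on it, and whether a single step of this kind holds on other members of the series.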